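Replacing a fluorophenyl with a dichlorophenyl on the ring amine

The compounds below may be only part of what the source reports. "The series", "measured", "known", "first", "only" and "open" are said of these compounds alone.

Of the compounds shown here, three sharing one core have been tested in a functional assay on DU-145 cells (Homo sapiens) for cytotoxicity, read by sulforhodamine B assay, with a stated time of 48 h; a higher number here means a weaker inhibitor of growth, a lower number a stronger inhibitor of growth. Compound 1 `COc1ccc(CN2CCN(c3nc(Nc4ccc(C#N)c(C(F)(F)F)c4)nc(Oc4ccnc5ccccc45)n3)CC2)c(OC)c1OC` is reported only as a limit there, and compound 1 gives > 100000 nM. Compound 2 `N#Cc1ccc(Nc2nc(Oc3ccnc4ccccc34)nc(N3CCN(c4ccccc4F)CC3)n2)cc1C(F)(F)F` is likewise reported only as a limit, and compound 2 gives > 100000 nM. Compound 3 `COc1ccc(N2CCN(c3nc(Nc4ccc(C#N)c(C(F)(F)F)c4)nc(Oc4ccnc5ccccc45)n3)CC2)cc1` is also reported only as a limit, and compound 3 gives > 100000 nM. Compound 2 therefore stands exactly where every other measured compound stands, at the limit described by the limit of > 100000 nM in this assay, at which 3 of the 3 values shown sit. Going by the values given here, the single measured step that changes compound 2 in one place, a step that the two limits leave unreadable from compound 2 to compound 3, cannot be sized, since both of its ends are limits.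

Compound 4 `N#Cc1ccc(Nc2nc(Oc3ccnc4ccccc34)nc(N3CCN(c4cccc(Cl)c4Cl)CC3)n2)cc1C(F)(F)F` differs from compound 2 by 2,3-dichlorophenyl in place of 2-fluorophenyl on an amine nitrogen in a ring. Among the compounds with values here, this change occupies the same position as the one measured step, which supplies no readable size. Within the data shown here, no measured step therefore bears on the move to compound 4 with a number, and nothing among the three results points away from the limit in this assay. Compound 4 is accordingly expected to remain at that limit, so the expected step that the limit leaves unreadable from compound 2 to compound 4 is taken as none beyond the scatter. The estimated outcome for compound 4 in this assay is 150000 nM, with a range from 30000 nM to 1000000 nM.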

Compound 4, concentration for total growth inhibition: > 100000 nM
Compound 4 gave a limit, no number; the forecaster's own chance of this, stated with the estimate: 85%; the middle value is on the limit's open side.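

In this assay compound 4 is reported only as a limit, > 100000 nM. The steps linking it to compound 2 and compound 3 therefore cannot be read, and the series sits at one place: the limit of > 100000 nM in this assay, at which 4 of the 4 values shown sit.

The compounds shown leave open which change on the ring amine or elsewhere on the shared core, if any, would give a readable number in this assay.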